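Para-substituent swap on the aryl group: fluoro to chloro

The compounds below may be only part of what the source reports. "The series", "measured", "known", "first", "only" and "open" are said of these compounds alone.

Measured compounds:
compound 1 `COc1ccccc1Oc1c(N)nc(-c2ccccc2F)nc1OCCO`: 11800 nM
compound 2 `COc1ccccc1Oc1c(N)nc(-c2ccc(F)cc2)nc1OCCO`: 30100 nM

Going by the values given here, in a functional assay on B16 cells (Mus musculus) for cytotoxicity, read by CCK-8 assay, with a stated time of 24 h (on this read-out lower numbers stand for stronger inhibition and higher numbers for weaker inhibition), compound 2 gives 30100 nM, the highest of the two numbers so far; its nearest neighbour, compound 1, gives 11800 nM. Among the compounds with values here, the only step recorded is a 2.6-fold higher number from compound 1 to compound 2 (0.41 log units; beyond the scatter), which moves the fluoro from one position of the phenyl ring to another. Compound 3 `COc1ccccc1Oc1c(N)nc(-c2ccc(Cl)cc2)nc1OCCO` differs from compound 2 by chloro in place of fluoro on an aromatic carbon. Within the data shown here, no measured pair swaps one halogen for another, so the recorded step does not bear directly on this change, and nothing points in either direction. The step from compound 2 to compound 3 in this assay is therefore expected to stay within the scatter, a 1.2-fold lower number from compound 2 to compound 3 (0.08 log units; within the scatter). Compound 3 is accordingly estimated at 25000 nM, with a range from 9000 nM to 70000 nM.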

Compound 3, half-maximal inhibitory concentration: 7740 nM
Estimate against measurement, compound 3: 3.2-fold (0.51 log units) above; measured number outside the range, below it.
By their numbers in this assay, from the lowest: compounds 3 and 1 (each within the scatter of the next); then compound 2.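

On a six-membered aromatic ring, para to a large group, the identity of the halogen matters and not only its place: chloro in place of fluoro gives a 3.9-fold lower number from compound 2 to compound 3 (0.59 log units; beyond the scatter) in this assay and so counts as a real change at this position. The higher number of compound 2 is therefore tied to fluoro at this place and not to any substituent there, since the 4-chlorophenyl and 2-fluorophenyl groups give a 1.5-fold lower number from compound 1 to compound 3 (0.18 log units; within the scatter) and are not separated. No accompanying data explain the halogen effect at this position.

Open, going by these compounds, is whether bromo, methyl, methoxy or an amine at this place would track with chloro or with fluoro. Also open, on these data alone, is what chloro would give at the place fluoro holds in compound 1.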